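The source may report more compounds than this note shows. Statements on the series, on what has been measured and on what is new or still open speak of the compounds shown alone.

For the measured compounds named here, in a functional assay (aorta) with Oryctolagus cuniculus as the target (on this read-out lower numbers stand for stronger inhibition and higher numbers for weaker inhibition), compound 2 `COCCO/C(O)=C1\C(C)=NC(C)=C(C(=O)OCCCN2C(=O)c3ccccc3S2(=O)=O)C1c1ccccc1C(F)(F)F` gives 1.4 nM, the lowest of the two numbers so far; compound 1 `COCCO/C(O)=C1\C(C)=NC(C)=C(C(=O)OCCCN2C(=O)c3ccccc3S2(=O)=O)C1c1cccc([N+](=O)[O-])c1` gives 6.8 nM, and the only step measured, a 4.9-fold lower number from compound 1 to compound 2 (0.69 log units; beyond the scatter), exchanges a different group from the one in question. Compound 3 `COCCO/C(O)=C1\C(C)=NC(C)=C(C(=O)OCCCN2C(=O)c3ccccc3S2(=O)=O)C1c1ccccc1Cl` carries the change (chloro in place of trifluoromethyl on an aromatic carbon). Going by the values given here, no measured step bears on this exchange by itself, so the size of the earlier step gives no direct guide. The step expected in this assay is small, a 1.4-fold higher number from compound 2 to compound 3 (0.15 log units; within the scatter), within the scatter in either direction. Compound 3 is therefore expected at 2 nM, with a range of 0.7 nM to 6 nM.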

Compound 3, half-maximal inhibitory concentration: 2.9 nM
Compound 3: the middle estimate sits 1.5-fold (0.16 log units) below what was measured; the measured number falls inside the stated range.
By their numbers in this assay, from the lowest: compound 2; then compound 3; then compound 1.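

The exchange of trifluoromethyl for chloro on this aromatic carbon now has a direct reading in this assay: a 2.1-fold higher number from compound 2 to compound 3 (0.32 log units; beyond the scatter) is a small but real loss. Chloro also keeps an advantage over the earlier aryl group, with a 2.3-fold lower number from compound 1 to compound 3 (0.37 log units; beyond the scatter) for 2-chlorophenyl in place of 3-nitrophenyl, so compound 2 and compound 3 both lie below compound 1. No supporting data explain this order. Open, as far as these compounds go, is how a methoxy group or a nitrile on this aromatic carbon would compare with chloro and trifluoromethyl.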